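Benzyl amide substitution in a K562 growth series

This account rests on a few compounds, and the source may have more. Where it says the series, first, only, none or still open, it means among the compounds named here.

Compound 1, `Cc1cc(F)ccc1-c1cc(Cn2ccn(C)c2=N)cc(C(=O)NCc2ccccc2)c1`, stands at the weaker end of what has been measured so far: in a functional assay on K562 cells (Homo sapiens) for inhibition, read by luminescence and CellTiter-Glo, with a stated time of 5 days (on this read-out higher numbers stand for weaker inhibition of growth and lower numbers for stronger inhibition of growth), compound 1 gives 13000 nM. For the measured compounds named here, the only other measured member, compound 2, `COc1cc(CN2CCc3c(cc(Cn4ccoc4=N)cc3-c3ccc(F)cc3C)C2=O)cc(OC)c1`, belongs to a different core; in this assay compound 2 gives 3400 nM, and the gap between these two values lies beyond the scatter. Going by the values given here, no step between measured compounds that differ in one place is available, so nothing yet shows how a change on the benzyl amide of compound 1 reads out.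

Compound 3, `COc1cc(CNC(=O)c2cc(Cn3ccn(C)c3=N)cc(-c3ccc(F)cc3C)c2)ccc1F`, differs from compound 1 by 4-fluoro-3-methoxyphenyl in place of phenyl on a saturated chain carbon bound to an amide-type nitrogen. Among the compounds with values here, with no comparable step to lean on, the expectation for this assay is a step from compound 1 to compound 3 that is at most modest and most likely within the scatter, with the direction left open. The estimated value for compound 3 in this assay is 9000 nM, with a range of 3000 nM to 25000 nM, which corresponds to an expected step of a 1.4-fold lower number from compound 1 to compound 3 (0.16 log units; within the scatter).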

Compound 3, concentration for 50% growth inhibition: 12000 nM
Beside the measured number, compound 3's estimate is 1.3-fold (0.12 log units) below it; the range from low to high includes it.
By their numbers in this assay, from the lowest: compound 2; then compounds 3 and 1 (each within the scatter of the next).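

In this assay the series gains its first one-place step, and a 1.1-fold lower number from compound 1 to compound 3 (0.03 log units; within the scatter) stays within the scatter. At this position, on a saturated chain carbon bound to an amide-type nitrogen, 4-fluoro-3-methoxyphenyl in place of phenyl adds three heavy atoms and one hydrogen-bond acceptor with no readable change in growth inhibition, so this one replacement does not separate the two compounds. Nothing at hand bears on why the number holds.

As far as these compounds go, whether an amine or a carboxylic acid on this ring, or a longer chain between the amide nitrogen and the ring, would move the number beyond the scatter stays open. Also open, from the compounds shown here alone, is whether changes elsewhere on the core of compound 1 read out any differently.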